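The source may report more compounds than this note shows. Statements on the series, on what has been measured and on what is new or still open speak of the compounds shown alone.

Compound 3 `CC(=O)N1N=C(c2ccc(-n3cncn3)cc2)CC1c1ccc(N(C)C)cc1` gives -0.3% in a functional assay on NCI-H1975 cells (Homo sapiens) for inhibition, read by sulforhodamine B assay, tested at 10 uM (on this read-out higher numbers stand for more inhibition at the one concentration tested (going by the name of the read-out) and lower numbers for less inhibition), the second highest of three numbers; compound 1 `Cc1ccc(C(=O)N2N=C(c3ccc(N4CCN(C)CC4)cc3)CC2c2ccc(N(C)C)cc2)cc1` gives -0.4%, which lies within the scatter of compound 3, while compound 2 `Cc1ccc(S(=O)(=O)N2N=C(c3ccc(N4CCN(C)CC4)cc3)CC2c2ccc(N(C)C)cc2)cc1` gives 38.1%, far beyond it. Compound 4 `CN(C)c1ccc(C2CC(c3ccc(-n4cncn4)cc3)=NN2S(=O)(=O)c2ccc(Br)cc2)cc1` differs from compound 3 in one place: (4-bromophenyl)sulfonyl in place of acetyl on an amine nitrogen in a ring. Within the data shown here, the one measured step that bears on this is a number 38.5 percentage points higher from compound 1 to compound 2 (beyond the scatter), where a (4-methylphenyl)sulfonyl replaced a (4-methylphenyl)carbonyl on the same ring nitrogen. Compound 4 likewise carries a sulfonyl where compound 3 carries acetyl, so a rise of comparable size is expected, a number 33.3 percentage points higher from compound 3 to compound 4 (beyond the scatter), though the acetyl and the bromine make the match imperfect. Compound 4 is therefore estimated at 33%, between 8% and 58%.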

Compound 4, a percentage reported as inhibition, at one concentration (the size of the read-out at that concentration, not a potency): -0.6%
Beside the measured number, compound 4's estimate is 33.6 percentage points above it; measured number outside the range, below it.
By their numbers in this assay, from the lowest: compounds 4, 1 and 3 (each within the scatter of the next); then compound 2.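

The step of a number 0.3 percentage points lower from compound 3 to compound 4 (within the scatter) in this assay shows that putting (4-bromophenyl)sulfonyl on this ring nitrogen does not by itself raise the number. The rise seen in the step of a number 38.5 percentage points higher from compound 1 to compound 2 (beyond the scatter) therefore does not hold for every sulfonyl swap, and compound 4 goes against it. Nothing measured here explains why the two steps differ.

As far as these compounds go, compound 2 and compound 4 differ in more than one place, so it remains open which difference matters. A plain methanesulfonyl on this nitrogen, or a morpholine on the other side of the shared core, could help separate them.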